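The compounds below may be only part of what the source reports. "The series", "measured", "known", "first", "only" and "open" are said of these compounds alone.

Three compounds share one core and differ only in the groups on the amide. Compound 1 `CSc1ccc2c(c1)c(O)c(C(=O)N(C)c1ccccc1)c(=O)n2C` carries a methyl and a phenyl on the amide-type nitrogen; in a functional assay on the whole organism for inhibition, with Mus musculus as the target, at a dose of 32 mg/kg by the oral route (a higher number here means more inhibition at the dose given (going by the name of the read-out), a lower number less inhibition), compound 1 gives 100%. Compound 2 `CSc1ccc2c(c1)c(O)c(C(=O)Nc1ccccc1)c(=O)n2C` has a hydrogen in place of that methyl, and compound 2 gives 24%, the lowest of the three numbers. Compound 3 `CSc1ccc2c(c1)c(O)c(C(=O)N(C)C1CCCCC1)c(=O)n2C` carries a cyclohexyl in place of the phenyl, and compound 3 gives 43%. The step of a number 76 percentage points lower from compound 1 to compound 2 (beyond the scatter) is the loss on removing the methyl; the step of a number 57 percentage points lower from compound 1 to compound 3 (beyond the scatter) is the loss on swapping the rings; the step of a number 19 percentage points higher from compound 2 to compound 3 (beyond the scatter) separates the two lower numbers.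

Compound 4 `CCN(C(=O)c1c(O)c2cc(SC)ccc2n(C)c1=O)c1ccccc1` is compound 2 with ethyl in place of hydrogen on an amide-type nitrogen. This undoes the change that took compound 1 to compound 2, except that the entering group is ethyl rather than methyl. Because compound 1 stands above compound 2 by a number 76 percentage points lower from compound 1 to compound 2 (beyond the scatter), a large rise is expected; no measurement shows how ethyl compares with methyl, so the range is wide. Compound 4 is expected to give 70%, between 35% and 100%. The expected step is a number 46 percentage points higher from compound 2 to compound 4 (beyond the scatter).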

Compound 4, a percentage reported as inhibition, in the whole organism at one dose (the size of the read-out at that dose, not a potency): 89%
Compound 4: the middle estimate sits 19 percentage points below what was measured; low and high end bracket the measured number.
By their numbers in this assay, from the lowest: compound 2; then compound 3; then compound 4; then compound 1.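

In this assay the amide-type nitrogen of compound 2 takes ethyl in place of hydrogen, and the step of a number 65 percentage points higher from compound 2 to compound 4 (beyond the scatter) shows that the large gain first seen with methyl is not limited to methyl. Adding one more carbon to that methyl changes much less: the step of a number 11 percentage points lower from compound 1 to compound 4 (beyond the scatter) is modest, though it lies beyond the scatter. With a phenyl on this nitrogen, both small saturated chains therefore stand far above hydrogen, and ethyl stands somewhat below methyl.

From the compounds shown here alone, whether this trend continues with a longer chain such as propyl or butyl, or how a chain ending in an amine or a carboxylic acid would behave here, remains open. Nothing available explains why the group on this nitrogen matters so much.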